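The compounds below may be only part of what the source reports. "The series", "measured", "known", "first", "only" and "open" are said of these compounds alone.

Of the compounds shown here, three of one shared core have been measured in a functional assay on Molt4/C8 cells (Homo sapiens) for cytotoxicity; a lower number here means a stronger inhibitor, a higher number a weaker inhibitor. Compound 1 `O=C(/C=C/C(=O)N1C/C(=C\c2ccccc2)C(=O)/C(=C/c2ccccc2)C1)Nc1ccc(Cl)c(Cl)c1` gives 1700 nM. Compound 3 `COc1ccc(NC(=O)/C=C/C(=O)N2C/C(=C\c3ccccc3)C(=O)/C(=C/c3ccccc3)C2)cc1` gives 1100 nM. The change between them, 4-methoxyphenyl in place of 3,4-dichlorophenyl on an amide-type nitrogen, gives a 1.5-fold lower number from compound 1 to compound 3 (0.19 log units; within the scatter). Compound 2 `CC(=O)c1ccc(NC(=O)/C=C/C(=O)N2C/C(=C\c3ccc([N+](=O)[O-])cc3)C(=O)/C(=C/c3ccc([N+](=O)[O-])cc3)C2)cc1` gives 390 nM, the lowest number of the three, and both other compounds stand beyond the scatter above it, so compound 2 is the strongest inhibitor measured so far.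

Compound 4 `Cc1ccc(NC(=O)/C=C/C(=O)N2C/C(=C\c3ccc([N+](=O)[O-])cc3)C(=O)/C(=C/c3ccc([N+](=O)[O-])cc3)C2)cc1` differs from compound 2 by methyl in place of acetyl on an aromatic carbon. Going by the values given here, no measured pair isolates this change; the only comparable step, that of the aryl group on the amide nitrogen from compound 1 to compound 3, stayed within the scatter. On that basis the writer expects the step of a 1.4-fold higher number from compound 2 to compound 4 (0.15 log units; within the scatter) to remain small, with no clear direction beyond the scatter. Compound 4 is therefore estimated at 550 nM, in a range from 250 nM to 1300 nM.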

Compound 4, half-maximal inhibitory concentration: 700 nM
The estimate for compound 4 lay 1.3-fold (0.10 log units) below the measured number, within the range that was stated.
By their numbers in this assay, from the lowest: compounds 2, 4, 3 and 1 (each within the scatter of the next, the first and the last beyond it).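

Exchanging acetyl for methyl on an aromatic carbon, para to a large group, gives a 1.8-fold higher number from compound 2 to compound 4 (0.25 log units; within the scatter) in this assay. Going by these compounds alone, this is the first measured step at this position with the rest of compound 2 held fixed, and it shows that the acetyl carbonyl, with its one hydrogen-bond acceptor, can be lost without a step beyond the scatter, so the earlier finding of a step within the scatter on this aryl group now also holds for a second pair with different remaining structure. No measurement at hand speaks to the cause of this result.

Still open, as far as these compounds go, is whether an amine or a carboxylic acid on this aromatic carbon would also stay within the scatter of compound 2. Equally open, from the compounds shown here alone, is whether the same exchange would give a similar step with the remaining structure of compound 1.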